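This account rests on a few compounds, and the source may have more. Where it says the series, first, only, none or still open, it means among the compounds named here.

Compound 3, `COc1cc(OC)cc(C(=O)N(CCC(=O)NCc2ccccc2)Cc2ccc(C(=O)NO)cc2)c1`, gives the highest number of the three compounds measured in a functional assay on G55T2 cells (Homo sapiens) for antiproliferative activity, read by WST assay, with a stated time of 72 h; on this read-out lower numbers stand for stronger inhibition and higher numbers for weaker inhibition: compound 3 gives 14700 nM. Its closest neighbour in the series is compound 2, `Cc1cc(C)cc(C(=O)N(CCC(=O)NCc2ccccc2)Cc2ccc(C(=O)NO)cc2)c1`, which in this assay gives 4250 nM, and the furthest is compound 1, `Cc1ccc(NC(=O)CCN(Cc2ccc(C(=O)NO)cc2)C(=O)c2cc(C)cc(C)c2)cc1`, which gives 370 nM. The move from compound 1 to compound 2 was large, an 11-fold higher number from compound 1 to compound 2 (1.06 log units; beyond the scatter), and the move from compound 2 to compound 3, a modest one, was a 3.5-fold higher number from compound 2 to compound 3 (0.54 log units; beyond the scatter).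

Compound 4, `CN(C)c1ccc(C(=O)N(CCC(=O)NCc2ccccc2)Cc2ccc(C(=O)NO)cc2)cc1`, differs from compound 3 in one place: 4-(dimethylamino)phenyl in place of 3,5-dimethoxyphenyl on a carbonyl carbon. For the measured compounds named here, only one measured step touches the same position, the exchange that separates compound 2 from compound 3, and that step raised the number by a 3.5-fold higher number from compound 2 to compound 3 (0.54 log units; beyond the scatter). Going by the values given here, no measured pair shows a 4-(dimethylamino)phenyl at this carbonyl carbon, so there is no direct precedent. The two aryl groups seen so far at this carbonyl carbon give numbers separated by only a modest step, so a third aryl group is expected to land in a similar region, with the step of a 1.8-fold lower number from compound 3 to compound 4 (0.26 log units; within the scatter) expected to stay near or within the scatter. Compound 4 is therefore estimated at 8000 nM, in a range from 2500 nM to 25000 nM.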

Compound 4, half-maximal inhibitory concentration: 1150 nM
Compound 4: middle estimate off by 7.0-fold (0.84 log units), on the high side; measured number below the stated range.
By their numbers in this assay, from the lowest: compound 1; then compound 4; then compound 2; then compound 3.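

At this carbonyl carbon, the 4-(dimethylamino)phenyl group gives a lower number than either earlier aryl group in this assay, with a 13-fold lower number from compound 3 to compound 4 (1.11 log units; beyond the scatter) and a 3.7-fold lower number from compound 2 to compound 4 (0.57 log units; beyond the scatter). The position therefore tolerates far more spread than the single exchange of 3,5-dimethoxyphenyl for 3,5-dimethylphenyl had shown, and the step away from 3,5-dimethoxyphenyl is as large as the one seen earlier on the amide-type nitrogen. Nothing available explains why this aryl group does better than the other two.

The compounds shown leave open whether the lower number goes with the dimethylamino group itself or with the change from a 3,5-disubstituted to a 4-substituted phenyl, since both change together here; 4-methoxyphenyl, 4-aminophenyl or 3,5-bis(dimethylamino)phenyl at this carbonyl carbon would separate the two. They also leave open whether the 4-(dimethylamino)phenyl group would keep its advantage with the 4-methylphenyl group of compound 1 on the amide-type nitrogen in place of benzyl, that is, whether the two changes would add up.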